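Working notes on the amide-to-ether exchange

The source may hold more compounds than are shown below. What is called first, only, known or untested is meant among the compounds shown, and "the series" means these compounds.

Compound 1 `Cc1nn(-c2ncnc3nc[nH]c23)c2c1C(C(=O)Nc1ccccc1)CC(=O)N2` carries phenylcarbamoyl on a saturated ring carbon of the shared core; in a functional assay on HEK293 cells for agonist activity at G-protein coupled receptor 39 (Homo sapiens), read by scintillation proximity assay and inositol phosphate accumulation, with a stated time of 75 min, in the presence of a further agent that is not named here (on this read-out higher numbers stand for an effect only at larger amounts of compound and lower numbers for an effect already at smaller amounts), compound 1 gives 10 nM. Among the three measured compounds it holds the second highest number. Compound 2 `Cc1cc(C)n(CCOC2CC(=O)Nc3c2c(C)nn3-c2ncnc3nc[nH]c23)n1` gives 16 nM and compound 3 `Cc1noc(C)c1COC1CC(=O)Nc2c1c(C)nn2-c1ncnc2nc[nH]c12` gives 5 nM. The steps of a 1.6-fold higher number from compound 1 to compound 2 (0.20 log units; within the scatter) and a 2.0-fold lower number from compound 1 to compound 3 (0.30 log units; within the scatter) both stay within the scatter, while a 3.2-fold lower number from compound 2 to compound 3 (0.51 log units; beyond the scatter) is a modest step beyond it.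

Going by the values given here, compound 4 `Cc1nn(-c2ncnc3nc[nH]c23)c2c1C(OCCn1nccc1C)CC(=O)N2` differs from compound 1 as follows. a group of 9 heavy atoms (6 carbon, 2 nitrogen, 1 oxygen; one five-membered aromatic ring with 2 hetero atoms) in place of a group of 9 heavy atoms (7 carbon, 1 nitrogen, 1 oxygen; one six-membered aromatic ring of carbon only), on a saturated ring carbon The entering group in compound 4 closely resembles the one present in compound 2 on the same saturated ring carbon, and that step, a 1.6-fold higher number from compound 1 to compound 2 (0.20 log units; within the scatter), lay within the scatter. Among the compounds with values here, nothing among the measured steps points to a change beyond the scatter for this kind of exchange. Compound 4 is therefore expected at 13 nM, within 5 nM to 35 nM. The expected step of a 1.3-fold higher number from compound 1 to compound 4 (0.11 log units; within the scatter) is estimated to remain within the scatter.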

Compound 4, half-maximal effective concentration: 10 nM
Beside the measured number, compound 4's estimate is 1.3-fold (0.11 log units) above it; measured number inside the range.
By their numbers in this assay, from the lowest: compounds 3, 1, 4 and 2 (each within the scatter of the next, the first and the last beyond it).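

The exchange of phenylcarbamoyl for the group in compound 4, with 0 hydrogen-bond donors and a five-membered aromatic ring with 2 hetero atoms, gives no change at the digits printed from compound 1 to compound 4 (within the scatter) in this assay, so this saturated ring carbon tolerates this ether-linked group as well as the amide. Removing the methyl on an aromatic carbon gives a 1.6-fold lower number from compound 2 to compound 4 (0.20 log units; within the scatter) and does not move the number beyond the scatter. The exchange of the ring on the chain now gives a 2.0-fold higher number from compound 3 to compound 4 (0.30 log units; within the scatter), whereas the step of a 3.2-fold lower number from compound 2 to compound 3 (0.51 log units; beyond the scatter) lay beyond it, so that modest separation does not hold for this pair. No supporting data bear on this result.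

Still open, on these data alone, is whether a dimethylamine or a carboxylic acid in place of the pyrazole ring would keep the number in this range. A longer chain between the oxygen and the ring is equally untested by the compounds shown.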